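The source may hold more compounds than are shown below. What is called first, only, known or untested is meant among the compounds shown, and "the series" means these compounds.

Compound 1 `CC(CCO)n1cnc2c(Cl)ncnc21` carries a chain that ends in a hydroxyl group and sits on a chlorinated bicyclic core. In a functional assay on SW480 cells (Homo sapiens) for antiproliferative activity, read by MTT assay, with a stated time of 48 h (a lower number here means a stronger inhibitor, a higher number a weaker inhibitor), compound 1 gives > 50000 nM, which is a limit of the assay rather than a number. Compound 2 `CCC(CCO)n1cnc2c(Cl)ncnc21` differs from compound 1 by methyl in place of hydrogen on a saturated chain carbon, two bonds along the chain from an aromatic nitrogen. In this assay compound 2 gives > 50000 nM, again a limit and not a number. The step that the two limits leave unreadable from compound 1 to compound 2 therefore cannot be read, because the limit of > 50000 nM in this assay, at which 2 of the 3 values shown sit, hides where either compound truly lies.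

Compound 3 `CCCCCC(CCO)n1cnc2c(Cl)nc(F)nc21` has a longer chain and a core carrying fluorine; how its core differs from that of compound 1 is not broken down here. In this assay compound 3 gives 7440 nM. Compound 4 `CCCCCCC(CCO)n1cnc2c(Cl)nc(F)nc21` differs from compound 3 by methyl in place of hydrogen on a saturated chain carbon, six bonds along the chain from an aromatic nitrogen, the same kind of change as between compound 1 and compound 2, though placed six bonds rather than two bonds along the chain from the aromatic nitrogen. Since the earlier step is unreadable, the expectation for compound 4 rests only on compound 3 and its value 7440 nM, and a small step of a 1.5-fold lower number from compound 3 to compound 4 (0.17 log units; within the scatter) is estimated. Compound 4 is expected to give about 5000 nM, within 1500 nM to 20000 nM.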

Compound 4, half-maximal inhibitory concentration: 12900 nM
Beside the measured number, compound 4's estimate is 2.6-fold (0.41 log units) below it, within the range that was stated.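

In this assay, methyl in place of hydrogen gives a 1.7-fold higher number from compound 3 to compound 4 (0.24 log units; within the scatter), so on the core carrying fluorine this change makes no difference that can be told from the usual scatter of repeated measurements. The same kind of change on the core of compound 1 cannot be read, because both of its compounds sit at a limit of the assay: the limit of > 50000 nM in this assay, at which 2 of the 4 values shown sit. The result therefore shows neither that the change carries over from one core to the other nor that it fails to, and the two changes also sit at different places, two and six bonds along the chain from an aromatic nitrogen.

The compounds shown leave open how a longer chain would read on the core of compound 4. They also leave open what an amine or a carboxylic acid would give in place of the hydroxyl at the chain end.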